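The compounds below may be only part of what the source reports. "The series", "measured", "known", "first", "only" and "open" are said of these compounds alone.

Measured so far:
compound 1, `COc1cc2nc(N3CCN(S(=O)(=O)c4ccc(Cl)cc4)CC3)nc(N)c2cc1OC`: 23000 nM
compound 2, `COc1cc2nc(N3CCN(S(=O)(=O)c4ccc(Cl)s4)CC3)nc(N)c2cc1OC`: 25000 nM
compound 3, `COc1cc2nc(N3CCN(S(=O)(=O)c4cccc([N+](=O)[O-])c4)CC3)nc(N)c2cc1OC`: 32000 nM

In a functional assay on PC-3 cells (Homo sapiens) for inhibition (on this read-out higher numbers stand for weaker inhibition and lower numbers for stronger inhibition), compound 1 holds the lowest of the three numbers, yet its two neighbours lie within the scatter of it: a 1.1-fold higher number from compound 1 to compound 2 (0.04 log units; within the scatter) and a 1.4-fold higher number from compound 1 to compound 3 (0.14 log units; within the scatter). The third pair, a 1.3-fold higher number from compound 2 to compound 3 (0.11 log units; within the scatter), is likewise within the scatter. Every one of these steps changes only the group on the sulfonyl sulfur, and none moves the number beyond the scatter.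

Compound 4, `COc1cc2nc(N3CCN(S(=O)(=O)c4ccc(C(C)(C)C)cc4)CC3)nc(N)c2cc1OC`, differs from compound 1 in the same region: tert-butyl in place of chloro on an aromatic carbon. Since all three measured exchanges at this position left the read-out unchanged within the scatter, no step beyond the scatter is expected here either. The expected step is a 1.1-fold higher number from compound 1 to compound 4 (0.04 log units; within the scatter). Compound 4 is therefore estimated at 25000 nM, between 9000 nM and 70000 nM.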

Compound 4, half-maximal inhibitory concentration: 4100 nM
For compound 4 the middle estimate is 6.1-fold (0.79 log units) above the measured one; measured number below the stated range.
By their numbers in this assay, from the lowest: compound 4; then compounds 1, 2 and 3 (each within the scatter of the next).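

Tert-butyl in place of chloro gives a 5.6-fold lower number from compound 1 to compound 4 (0.75 log units; beyond the scatter) in this assay and so shows that the aromatic carbon carrying this group can move the number beyond the scatter. Compound 4 also separates from the other two sulfonyl groups, with a 6.1-fold lower number from compound 2 to compound 4 (0.79 log units; beyond the scatter) and a 7.8-fold lower number from compound 3 to compound 4 (0.89 log units; beyond the scatter) as further steps, a separation that none of the exchanges among compounds 1, 2 and 3 had shown. No measurement here bears on why tert-butyl and chloro differ at this carbon.

On these data alone, whether methyl, isopropyl, a longer chain or an amine on the same carbon would give a number like that of compound 4 remains open.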